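A Chain Swap on the Potent Carbamate Compound 2

The compounds below may be only part of what the source reports. "The series", "measured", "known", "first", "only" and "open" are said of these compounds alone.

The set begins with compound 1 `CCCCNC(=O)Oc1cccc(-n2ccc(C(N)=O)c2)c1`, which in an assay (brain) for inhibition of Fatty-acid amide hydrolase 1 (Mus musculus), with stated times of 20 min and 15 min (a higher number here means a weaker inhibitor, a lower number a stronger inhibitor), gives 240 nM. Compound 2 `NC(=O)c1ccn(-c2cccc(OC(=O)NCCCCCCc3ccccc3)c2)c1` carries the same core and in this assay gives 0.6 nM, the lowest number among the three measured compounds; compound 3 `Cc1oc(-c2cccc(OC(=O)NCCCCCCc3ccccc3)c2)cc1C(N)=O` gives 18 nM. The two steps that connect them are large: a 400-fold lower number from compound 1 to compound 2 (2.60 log units; beyond the scatter), and a 30-fold higher number from compound 2 to compound 3 (1.48 log units; beyond the scatter).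

Compound 4 `NC(=O)c1ccn(-c2cccc(OC(=O)NCCOCCOc3ccccc3)c2)c1` is not yet measured. It differs from compound 2 in one place: 2-phenoxyethoxy in place of 4-phenylbutyl on a saturated chain carbon, two bonds along the chain from an amide-type nitrogen. Within the data shown here, the step that bears most on this change is the one from compound 1 to compound 2, where extending the chain by a phenethyl group lowered the number sharply; compound 4 keeps a chain of the same length and the same terminal ring, so that gain should largely survive. The step from compound 2 to compound 3 alters the core rather than the chain and offers little guidance here. With nothing measured on oxygen-containing chains, a moderate rise beyond the scatter is expected rather than a collapse back toward compound 1.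

In this assay compound 4 is therefore estimated at 5 nM, within a range from 1 nM to 30 nM, and the expected step is an 8.3-fold higher number from compound 2 to compound 4 (0.92 log units; beyond the scatter).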

Compound 4, half-maximal inhibitory concentration: 87 nM
For compound 4 the middle estimate is 17-fold (1.24 log units) below the measured one, outside the stated range (above it).
By their numbers in this assay, from the lowest: compound 2; then compound 3; then compound 4; then compound 1.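

In this assay, putting 2-phenoxyethoxy in place of 4-phenylbutyl on a saturated chain carbon, two bonds along the chain from an amide-type nitrogen, gives a 150-fold higher number from compound 2 to compound 4 (2.16 log units; beyond the scatter) even though both groups have 10 heavy atoms and one six-membered aromatic ring of carbon only. The exchange of carbon for 2 oxygen atoms, which brings 2 hydrogen-bond acceptors, is therefore enough to change the number at this position by a large step, so the heavy-atom count and terminal ring do not by themselves secure the low number of compound 2. Against the shorter chain, the new chain gives only a 2.8-fold lower number from compound 1 to compound 4 (0.44 log units; beyond the scatter) and so keeps little of the large drop seen with compound 2, and nothing available here explains the loss.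

The compounds shown leave open whether a single ether oxygen in the chain would produce a step of similar size, since the two oxygen atoms enter together in 2-phenoxyethoxy. They also leave open how an amine or a longer ether chain would read at this position, and whether 2-phenoxyethoxy would produce a comparable step on the core of compound 3.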